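The source may report more compounds than this note shows. Statements on the series, on what has been measured and on what is new or still open speak of the compounds shown alone.

Measured in a physicochemical assay for acid dissociation, read by capillary electrophoresis, tested at 100 uM:
Compound 1 `CONC(=O)CCc1ccccc1`: 9.47
Compound 2 `CS(=O)(=O)NC(=O)CCc1ccccc1`: 4.94

Compound 2 holds the lower of the two numbers. Within the data shown here, the only measured step, a number 4.53 log units lower from compound 1 to compound 2 (beyond the scatter), is large and beyond the scatter, and it put methylsulfonyl in place of methoxy on an amide-type nitrogen. Compound 3 `CN(C)S(=O)(=O)NC(=O)CCc1ccccc1` has dimethylamino in place of methyl on a sulfonyl sulfur. Among the measured compounds shown here, it keeps the sulfonyl group, and no measured step covers the new exchange, so a number 4.53 log units lower from compound 1 to compound 2 (beyond the scatter) bears only loosely. A small upward shift in this assay is expected, perhaps none beyond the scatter. The expected step is a number 0.26 log units higher from compound 2 to compound 3 (within the scatter). Compound 3 is estimated at 5.2, with an expected range of 4.7 to 5.8.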

Compound 3, acid dissociation constant: 5.86
Estimate against measurement, compound 3: 0.66 log units below; measured number above the stated range.
By their numbers in this assay, from the lowest: compound 2; then compound 3; then compound 1.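

With dimethylamino in place of methyl on a sulfonyl sulfur, this assay gives a number 0.92 log units higher from compound 2 to compound 3 (beyond the scatter), a modest step. The earlier step changed the group on the amide-type nitrogen, whereas this one keeps the sulfonyl group and shows that the substituent on the sulfonyl sulfur alone can move the number beyond the scatter. Nothing available explains this shift.

From the compounds shown here alone, it remains open how other groups on the sulfonyl sulfur, such as methylamino, morpholine or phenyl, would compare with methyl and dimethylamino. Going by these compounds, a longer chain, such as ethyl, is equally open.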